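Lengthening the Amine Side Chain of Compound 1

A few compounds are considered here, and "the series" means these few. Any claim that something is new, unique, unknown or untested is made for them only; others in the source may bear on it.

Of the compounds shown here, three sharing one core have been measured in a functional assay on C6 cells (Rattus norvegicus) for cytotoxicity, read by MTT assay, with a stated time of 24 h; on this read-out lower numbers stand for stronger inhibition and higher numbers for weaker inhibition. Compound 1 `CN(C)CCN1CCN(CC(=O)Nc2ccc(-c3nc4cc(Cl)ccc4o3)cc2)CC1` gives 1030 nM, the lowest of the three numbers. Compound 2 `CN(C)CCN1CCN(CC(=O)Nc2ccc(-c3nc4ccccc4o3)cc2)CC1` gives 7010 nM, and compound 3 `Cc1cc(-c2nc3cc(Cl)ccc3o2)ccc1NC(=O)CN1CCN(CCN(C)C)CC1` gives 13500 nM. Both changes leading away from compound 1 raised the number: a 6.8-fold higher number from compound 1 to compound 2 (0.83 log units; beyond the scatter), and a 13-fold higher number from compound 1 to compound 3 (1.12 log units; beyond the scatter). Each of these steps concerns an aromatic carbon, and neither touches the basic side chain.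

Compound 4 `CN(C)CCCN1CCN(CC(=O)Nc2ccc(-c3nc4cc(Cl)ccc4o3)cc2)CC1` differs from compound 1 in exactly that side chain: (dimethylamino)methyl in place of dimethylamino on a saturated chain carbon, two bonds along the chain from an amine nitrogen in a ring. The chain grows by one link, while the amine at its end is kept. Among the measured steps, none bears on this kind of change; the only steps available concern substituents on aromatic carbons, and the side chain has not been varied in any measured pair. For the measured compounds named here, with no comparable step to lean on, the expectation for this change in this assay is a step within the scatter, in no particular direction, and the estimated step is a 1.1-fold higher number from compound 1 to compound 4 (0.03 log units; within the scatter). Compound 4 is therefore expected to give about 1100 nM in this assay, with a range from 400 nM to 3500 nM.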

Compound 4, half-maximal inhibitory concentration: 910 nM
Beside the measured number, compound 4's estimate is 1.2-fold (0.08 log units) above it; the measured number falls inside the stated range.
By their numbers in this assay, from the lowest: compounds 4 and 1 (each within the scatter of the next); then compounds 2 and 3 (each within the scatter of the next).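

Of the steps in this series, this is the only one on the side chain; the others sit on aromatic carbons and lie beyond the scatter. In this assay, going from 2-(dimethylamino)ethyl to 3-(dimethylamino)propyl gives a 1.1-fold lower number from compound 1 to compound 4 (0.05 log units; within the scatter), so this position accepts that added chain length without a change that can be told from repeat scatter. No measurement here explains why the lengthening leaves the number where it was.

One step on one chain cannot show whether the same holds for a still longer chain, such as 4-(dimethylamino)butyl, or for a shorter one. It also leaves open whether the amine at the chain end matters, which a diethylamino group or a hydroxyl in place of the dimethylamino would test.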